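Swapping the phenethyl arm of compound 1 for a methoxyphenyl ring

The compounds below may be only part of what the source reports. "The series", "measured", "known", "first", "only" and "open" are said of these compounds alone.

Measured so far:
Compound 1, `C=C(Br)C(=O)Nc1cccc(-c2cn3nc(CCc4ccccc4)sc3n2)c1`, gives 2600 nM.
Compound 2, `CCc1ccc(-c2nn3cc(-c4cccc(N)c4)nc3s2)cc1`, gives 8200 nM.
Compound 3, `Nc1cccc(-c2cn3nc(-c4ccccc4)sc3n2)c1`, gives 14000 nM.

All three were tested in a functional assay on FM3A cells (Mus musculus) for inhibition, read by cell counting, with a stated time of 2 days; on this read-out lower numbers stand for stronger inhibition and higher numbers for weaker inhibition. On these numbers compound 1 stands lowest; compound 2 is nearest to it and compound 3 furthest, both gaps lying beyond the scatter.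

Compound 4, `C=C(Br)C(=O)Nc1cccc(-c2cn3nc(-c4ccc(OC)cc4)sc3n2)c1`, has not yet been measured. It keeps the bromoacrylamide of compound 1 and changes only the group on the five-membered aromatic ring of the shared core: 4-methoxyphenyl in place of phenethyl on an aromatic carbon.

Going by the values given here, only one measured step touches the same position. There, a 1.7-fold higher number from compound 2 to compound 3 (0.23 log units; within the scatter), so the change from ethyl to hydrogen on a six-membered aromatic ring at this spot hardly moved the number. Among the compounds with values here, no measured pair compares phenethyl with an aryl group directly, so that part of the change is unsupported by data. Within the data shown here, because the sole step at this position, a 1.7-fold higher number from compound 2 to compound 3 (0.23 log units; within the scatter), lies within the scatter, the expectation for compound 4 is a number close to that of compound 1, with an estimated step of a 1.2-fold higher number from compound 1 to compound 4 (0.06 log units; within the scatter) and no expected direction beyond the scatter. The estimate for compound 4 is 3000 nM, in an expected range from 900 nM to 10000 nM.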

Compound 4, half-maximal inhibitory concentration: 890 nM
Compound 4: the middle estimate sits 3.4-fold (0.53 log units) above what was measured, and the stated range ends above it.
By their numbers in this assay, from the lowest: compound 4; then compound 1; then compounds 2 and 3 (each within the scatter of the next).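

In this assay, going by these compounds alone, this is the first change at this position that moves the number beyond the scatter: a 2.9-fold lower number from compound 1 to compound 4 (0.47 log units; beyond the scatter). Within the data shown here, the only earlier step here, a 1.7-fold higher number from compound 2 to compound 3 (0.23 log units; within the scatter), stayed within the scatter, and it concerned a small ethyl group on a compound with a free amine rather than the bromoacrylamide. The new step shows that, with the bromoacrylamide held fixed, the number can shift even when the entering and leaving groups match in heavy-atom count and each carries one six-membered aromatic ring of carbon only. Nothing shown here gives a reason for this shift.

The change replaces the two-carbon link of phenethyl with a ring bonded straight to the core and also adds a methoxy group, and the compounds shown cannot tell these two parts apart; an unsubstituted phenyl ring alongside the bromoacrylamide would begin to do so. Also open, going by these compounds, is how other groups at this position would compare, such as a 4-hydroxyphenyl ring, a 4-chlorophenyl ring or a longer chain like phenylpropyl.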